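The source may hold more compounds than are shown below. What is called first, only, known or untested is meant among the compounds shown, and "the series" means these compounds.

Measured so far in an ADME assay on A549 cells (Homo sapiens) for inhibition, read by MTT assay, with a stated time of 48 h; a lower number here means a stronger inhibitor of growth, a higher number a weaker inhibitor of growth:
- compound 1 `Clc1ccc(Cn2cc(COc3ccccc3)nn2)cc1` gives > 100 ug/mL, a limit of the assay rather than a number.
- compound 2 `Clc1cccc(Cn2cc(COc3ccccc3)nn2)c1` gives > 100 ug/mL, likewise a limit.
- compound 3 `Clc1ccc(Cn2cc(COc3ccc(Cl)cc3)nn2)cc1` gives > 100 ug/mL, likewise a limit.

All three values sit at the limit of > 100 ug/mL in this assay, at which 3 of the 3 values shown sit, so no ordering among them can be read. The step that the two limits leave unreadable from compound 1 to compound 2 is unreadable for that reason, as is a step that the two limits leave unreadable from compound 1 to compound 3. The change from compound 1 to compound 2 is 3-chlorophenyl in place of 4-chlorophenyl on a saturated chain carbon bound to an aromatic nitrogen. The same change, at the same place, is made from compound 3 to compound 4 `Clc1ccc(OCc2cn(Cc3cccc(Cl)c3)nn2)cc1`: 3-chlorophenyl in place of 4-chlorophenyl on a saturated chain carbon bound to an aromatic nitrogen. The two cores differ by chloro in place of hydrogen on an aromatic carbon.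

For compound 4 the step that the limit leaves unreadable from compound 3 to compound 4 is expected to be negligible, because the matching step that the two limits leave unreadable from compound 1 to compound 2 left compound 1 and compound 2 both at the limit. Compound 4 is accordingly estimated at 150 ug/mL, most probably reported again only as a limit.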

Compound 4, concentration for 50% growth inhibition: > 100 ug/mL
Compound 4 was reported as a limit; the forecaster's own chance of this, stated with the estimate: 85%; the middle value does not contradict the limit.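

In this assay compound 4 gives > 100 ug/mL, again a limit of the assay. No step from compound 2 or compound 3 to compound 4 can be read: the limit of > 100 ug/mL in this assay, at which 4 of the 4 values shown sit.

The compounds shown leave open whether either change alters growth inhibition at all.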